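The compounds below may be only part of what the source reports. "The series", "measured", "known", "first", "only" and "open" are said of these compounds alone.

- Compound 1 `O=C1/C(=C/c2cccnc2)CNC/C1=C\c1ccccc1F` gives 21000 nM
- Compound 2 `Cc1ccc(S(=O)(=O)N2C/C(=C\c3cccnc3)C(=O)/C(=C/c3ccccc3F)C2)cc1` gives 4200 nM
- Compound 3 `O=C1/C(=C/c2cccnc2)CN(S(=O)(=O)c2ccc(C(F)(F)F)cc2)C/C1=C\c1ccccc1F` gives 2400 nM

These numbers come from a functional assay on HepG2 cells (Homo sapiens) for cytotoxicity, read by MTT assay, with a stated time of 24 h (a higher number here means a weaker inhibitor, a lower number a stronger inhibitor), and serve here as a guide to compound 4 `O=C1/C(=C/c2cccnc2)CN(S(=O)(=O)c2ccc(Br)cc2)C/C1=C\c1ccccc1F` which has not yet been measured. Compound 3 stands within the scatter of compound 2 and well under compound 1 on this scale. The change leading to compound 4 is bromo in place of trifluoromethyl on an aromatic carbon or, in words, bromo in place of trifluoromethyl on an aromatic carbon, para to a large group.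

Two measured steps are available. The step of a 5.0-fold lower number from compound 1 to compound 2 (0.70 log units; beyond the scatter) is modest but beyond the scatter. It put (4-methylphenyl)sulfonyl in place of hydrogen on an amine nitrogen in a ring, and compound 4 keeps a sulfonyl group there, so this step says little about the new change. The closer guide is a 1.8-fold lower number from compound 2 to compound 3 (0.24 log units; within the scatter) at the same place, and it stays within the scatter. Within the data shown here, no bromo compound has been measured yet, so no step beyond the scatter is expected in this assay here. The expected step is a 1.1-fold higher number from compound 3 to compound 4 (0.03 log units; within the scatter) and should stay within the scatter. For compound 4 the estimated value is 2600 nM with an expected range from 1200 nM to 5500 nM in this measurement.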

Compound 4, half-maximal inhibitory concentration: 8700 nM
Beside the measured number, compound 4's estimate is 3.3-fold (0.52 log units) below it; the whole stated range lies below it.
By their numbers in this assay, from the lowest: compounds 3 and 2 (each within the scatter of the next); then compound 4; then compound 1.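

In this assay, the group on this aromatic carbon, para to a large group, turns out to matter: bromo in place of trifluoromethyl gives a 3.6-fold higher number from compound 3 to compound 4 (0.56 log units; beyond the scatter) and bromo in place of methyl gives a 2.1-fold higher number from compound 2 to compound 4 (0.32 log units; beyond the scatter), so compound 4 separates from two neighbours that sit within the scatter of each other. The (4-bromophenyl)sulfonyl group still improves on hydrogen at the ring nitrogen, with a 2.4-fold lower number from compound 1 to compound 4 (0.38 log units; beyond the scatter) as the step, so this sulfonyl group keeps a lower number than the unsubstituted amine whichever of the three aromatic groups it carries. Nothing available here explains why bromo differs from methyl and trifluoromethyl at this position.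

The compounds shown leave open how a methoxy group, an amine or a carboxylic acid would read on this same aromatic carbon. They also leave open whether chloro or iodo would follow bromo.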